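Swapping 2-methoxyphenyl for 4-methoxyphenyl on the carbonyl

The source may report more compounds than this note shows. Statements on the series, on what has been measured and on what is new or still open speak of the compounds shown alone.

Of the compounds shown here, three built on a shared core have been tested in a functional assay on HepG2 cells (Homo sapiens) for inhibition, read by MTT assay, with a stated time of 24 h; a higher number here means a weaker inhibitor of growth, a lower number a stronger inhibitor of growth. Compound 1 `COc1ccc(C(=O)n2c(-c3cn(C)c4ccccc34)nc3ccccc32)cc1` gives 15200 nM, compound 2 `COc1ccc(C(=O)n2c(-c3cn(C)c4ccc(OC)cc34)nc3ccccc32)cc1` gives 12800 nM, and compound 3 `COc1ccccc1C(=O)n1c(-c2cn(C)c3ccc(Br)cc23)nc2ccccc21` gives 34600 nM. That last number is the highest of the three, and its gaps to the other two lie beyond the usual scatter, so compound 3 is the weakest growth inhibitor of this small set.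

Compound 4 `COc1ccc(C(=O)n2c(-c3cn(C)c4ccc(Br)cc34)nc3ccccc32)cc1` has not yet been measured. It differs from compound 3 in a single place, with 4-methoxyphenyl in place of 2-methoxyphenyl on a carbonyl carbon.

Going by the values given here, the only measured step, a 1.2-fold lower number from compound 1 to compound 2 (0.07 log units; within the scatter), is a different change and lies within the scatter, so it says little about this swap. Among the compounds with values here, no measured pair isolates the swap itself. The one hint is indirect: the 4-methoxyphenyl group is carried by compound 1 at 15200 nM and by compound 2 at 12800 nM, although compound 3 also differs from them in another place. A move towards a lower number therefore seems likely, but it is uncertain.

The expected change is a 2.2-fold lower number from compound 3 to compound 4 (0.33 log units; beyond the scatter). For compound 4 the estimated value is 16000 nM, with an expected range from 7000 nM to 35000 nM.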

Compound 4, concentration for 50% growth inhibition: 18900 nM
Beside the measured number, compound 4's estimate is 1.2-fold (0.07 log units) below it; low and high end bracket the measured number.
By their numbers in this assay, from the lowest: compounds 2, 1, 4 and 3 (each within the scatter of the next, the first and the last beyond it).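

Read directly for the first time in this assay, the swap on the carbonyl carbon gives a 1.8-fold lower number from compound 3 to compound 4 (0.26 log units; within the scatter) and so cannot be separated from ordinary assay variation. With 4-methoxyphenyl held constant, compound 4 also allows two comparisons on an aromatic carbon of the shared core: bromo in place of methoxy gives a 1.5-fold higher number from compound 2 to compound 4 (0.17 log units; within the scatter) and bromo in place of hydrogen gives a 1.2-fold higher number from compound 1 to compound 4 (0.09 log units; within the scatter), so hydrogen, methoxy and bromo at this site cannot be told apart in this assay. Nothing available here offers an explanation for these results.

Going by these compounds, compound 3 alone carries 2-methoxyphenyl, so it remains open whether this swap would read the same with hydrogen or methoxy in place of the bromo. On these data alone, it also remains open whether a phenyl ring carrying an amine or a carboxylic acid in place of the methoxy, or a longer chain such as butoxy, would move the number beyond the scatter.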